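A few compounds are considered here, and "the series" means these few. Any claim that something is new, unique, unknown or untested is made for them only; others in the source may bear on it.

Of the compounds shown here, two of a shared core have been measured in a functional assay (aorta) with Rattus norvegicus as the target; a lower number here means a less potent compound, a higher number a more potent compound, by a factor of ten per unit of this negative logarithm. Compound 1 `CC1(C)C=C(n2ccccc2=O)c2cc(C(=N)NO)ccc2O1` gives 5.99 in this assay, and compound 2 `CC1(C)C=C(n2ccccc2=O)c2cc(OC(=O)Nc3ccc(C(F)(F)F)cc3)ccc2O1` gives 5.1. Compound 1 therefore stands higher of the two, and the gap to compound 2 is beyond the scatter of repeated measurements.

Compound 3 `CC1(C)C=C(n2ccccc2=O)c2cc(Br)ccc2O1` has not yet been measured in this assay. It differs from compound 1 in one place: one bromine atom in place of a group of 4 heavy atoms (1 carbon, 2 nitrogen, 1 oxygen; no ring), on an aromatic carbon. The change removes three hydrogen-bond donors and two acceptors from that aromatic carbon and leaves a single heavy atom in their place.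

Going by the values given here, no step between two measured compounds of this kind is available, so the expectation rests on the two values alone. The step of a number 0.19 log units lower from compound 1 to compound 3 (within the scatter) is expected to fall within the scatter. For compound 3 the estimate in this assay is 5.8, with a range from 5 to 6.6.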

Compound 3, logarithm of the reciprocal of the active concentration, log(1/C): 7.84
Beside the measured number, compound 3's estimate is 2.04 log units below it, outside the stated range (above it).
By their numbers in this assay, from the lowest: compound 2; then compound 1; then compound 3.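

In this assay, putting one bromine atom on this aromatic carbon gives a number 1.85 log units higher from compound 1 to compound 3 (beyond the scatter), so the largest number among the compounds shown comes from the smallest substituent. A high number at this position therefore requires none of the hydrogen-bond donors or acceptors of the group that leaves, which the earlier pair of compounds could not show. No measurement given here accounts for the size of this rise.

The compounds shown leave open whether the gain is specific to bromine or would also appear with a chlorine atom, a methyl group or a nitrile on the same aromatic carbon. They also do not show how the unsubstituted carbon, with only a hydrogen atom there, would compare with compound 3.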